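Isobutyl in place of ethyl: notes on compound 4

The source may report more compounds than this note shows. Statements on the series, on what has been measured and on what is new or still open speak of the compounds shown alone.

In a physicochemical assay for permeability, using PAMPA (a higher number here means that the compound crosses the layer faster, a lower number that the compound crosses the layer more slowly), compound 1 `Cc1ccc([C@@H](C)Oc2cc3oc(=O)n(CCC(=O)O)c3cc2Cl)nc1` gives 22 nm/s. Compound 2 `O=C(O)CCn1c(=O)oc2cc(OCC3CCC3)c(Cl)cc21` gives 12 nm/s. Compound 3 `CCc1cc2oc(=O)n(CCC(=O)O)c2cc1Cl` is reported only as a limit, < 10 nm/s. Compound 4 `CC(C)Cc1cc2oc(=O)n(CCC(=O)O)c2cc1Cl` differs from it in one place, ethyl to isobutyl: isopropyl in place of methyl on a saturated chain carbon bound to an aromatic carbon. For the measured compounds named here, the one measured step that bears on this, an at least 1.2-fold lower number from compound 2 to compound 3 (0.07 log units; that floor lies within the scatter), is a floor within the scatter and gives no full size, so no step beyond the scatter is expected in this assay, in either direction. The estimated step is an at least 1.1-fold higher number from compound 3 to compound 4 (0.04 log units; that floor lies within the scatter). For compound 4 the expected value is 11 nm/s, with an estimated range of 5 nm/s to 25 nm/s.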

Compound 4, apparent permeability: < 10 nm/s
Compound 4: a limit, no number; the forecaster's own chance of this, stated with the estimate: 50%; at least 1.1-fold (0.04 log units) between middle value and limit.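

In this assay compound 4 is reported only as a limit, < 10 nm/s, not as a number. Isobutyl in place of ethyl thus leaves this position at the same limit as compound 3, and the step between the two cannot be read because both sit there: the limit of < 10 nm/s in this assay, at which 2 of the 4 values shown sit. The one readable step, an at least 1.2-fold lower number from compound 2 to compound 4 (0.07 log units; that floor lies within the scatter), gives only a floor.

From the compounds shown here alone, how far under the limit compound 3 and compound 4 lie stays open. So does what a longer chain or an amine on this aromatic carbon would give.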